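Replacing the ethylpiperazine arm with a thiazolidinedione

The source may report more compounds than this note shows. Statements on the series, on what has been measured and on what is new or still open speak of the compounds shown alone.

Compound 1 `CCN1CCN(C[C@H]2CN(c3ccc(-n4cc(-c5ccccn5)cn4)c(F)c3)C(=O)O2)CC1` stands highest of the three measured compounds in a physicochemical assay for lipophilicity, read by HPLC, measured as octanol-water partition (a higher number here means a more lipophilic compound, a lower number a more polar compound), at 2.19. Compound 2 `COC(=O)CC1CCN(C[C@H]2CN(c3ccc(-n4cc(-c5ccccn5)cn4)c(F)c3)C(=O)O2)CC1` gives 1.78 in this assay, and compound 3 `O=C1CCC(=O)N1C[C@H]1CN(c2ccc(-n3cc(-c4ccccn4)cn3)c(F)c2)C(=O)O1` gives 1.58. The steps of a number 0.41 log units lower from compound 1 to compound 2 (beyond the scatter) and a number 0.61 log units lower from compound 1 to compound 3 (beyond the scatter) both lower the number beyond the scatter, whereas the step of a number 0.20 log units lower from compound 2 to compound 3 (within the scatter) stays within it, so compound 2 and compound 3 cannot be ordered against each other on these numbers.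

Compound 4 `O=C1CSC(=O)N1C[C@H]1CN(c2ccc(-n3cc(-c4ccccn4)cn3)c(F)c2)C(=O)O1` has not yet been measured in this assay. It differs from compound 1 by 2,4-dioxo-1,3-thiazolidin-3-yl in place of 4-ethylpiperazin-1-yl on a saturated chain carbon bound to a saturated ring carbon. The entering 2,4-dioxo-1,3-thiazolidin-3-yl is the near counterpart of the 2,5-dioxopyrrolidin-1-yl carried by compound 3, so the step from compound 1 to compound 3 is the closest guide; the step from compound 1 to compound 2 points the same way. A lowering beyond the scatter is therefore expected, a number 0.59 log units lower from compound 1 to compound 4 (beyond the scatter), because a number 0.61 log units lower from compound 1 to compound 3 (beyond the scatter) describes the same kind of exchange at the same place. For compound 4 the estimate in this assay is 1.6, with a range from 1.2 to 2.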

Compound 4, partition coefficient: 2.18
Compound 4: the middle estimate sits 0.58 log units below what was measured; the whole stated range lies below it.
By their numbers in this assay, from the lowest: compounds 3 and 2 (each within the scatter of the next); then compounds 4 and 1 (each within the scatter of the next).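

In this assay, the exchange of 4-ethylpiperazin-1-yl for 2,4-dioxo-1,3-thiazolidin-3-yl on a saturated chain carbon bound to a saturated ring carbon reads as a number 0.01 log units lower from compound 1 to compound 4 (within the scatter), so compounds 1 and 4 cannot be ordered, and losing the 4-ethylpiperazin-1-yl does not by itself bring a lowering at this place. The two five-membered diones do not read as counterparts here: the exchange of 2,5-dioxopyrrolidin-1-yl for 2,4-dioxo-1,3-thiazolidin-3-yl gives a number 0.60 log units higher from compound 3 to compound 4 (beyond the scatter), so the value of one ring is no guide to the other. The exchange from the 4-((methoxycarbonyl)methyl)piperidin-1-yl arm gives a number 0.40 log units higher from compound 2 to compound 4 (beyond the scatter), and nothing shown accounts for these differences.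

As far as these compounds go, whether the ring sulfur or the arrangement of the two carbonyls separates the two diones stays open, and an oxazolidine-2,4-dione ring, with oxygen in place of that sulfur, would bear on this. Also open, from the compounds shown here alone, is how a free carboxylic acid in place of the methyl ester of compound 2 would read at this place.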